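This account rests on a few compounds, and the source may have more. Where it says the series, first, only, none or still open, it means among the compounds named here.

In a functional assay on HUVEC cells (Homo sapiens), read by BrdU incorporation, with a stated time of 72 h (on this read-out higher numbers stand for weaker inhibition and lower numbers for stronger inhibition), compound 1 (`Cc1ccc2nc(Cl)c(/C=C/C(=O)c3sccc3C)cc2c1`) gives 127 nM and compound 2 (`Cc1ccc2cc(/C=C/C(=O)c3ccc(I)s3)c(Cl)nc2c1`) gives 135 nM on the same read-out. Going by the values given here, these two values lie within the scatter of each other, so compound 1 stands level with compound 2 on the numbers so far. Among the compounds with values here, the two structures differ in more than one place, and no single-change step between measured compounds exists to size the next change. Compound 3 (`Cc1ccc2nc(Cl)c(/C=C/C(=O)c3ccc(Br)s3)cc2c1`) has not been measured yet. It keeps the core of compound 1 and takes 5-bromothiophen-2-yl in place of 3-methylthiophen-2-yl on a carbonyl carbon. Within the data shown here, with no measured step as a guide, no shift beyond the scatter is expected in this assay in either direction, and the expectation takes compound 1 at 127 nM as its starting point. The estimated change is small, with a 1.0-fold higher number from compound 1 to compound 3 (0.01 log units; within the scatter) as the expected step. For compound 3 the estimated value is 130 nM with an expected range from 50 nM to 340 nM in this measurement.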

Compound 3, half-maximal inhibitory concentration: 88.4 nM
Compound 3: the middle estimate sits 1.5-fold (0.17 log units) above what was measured; the measured number falls inside the stated range.
By their numbers in this assay, from the lowest: compounds 3, 1 and 2 (each within the scatter of the next).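

With a step now available at this position, 5-bromothiophen-2-yl in place of 3-methylthiophen-2-yl on a carbonyl carbon gives a 1.4-fold lower number from compound 1 to compound 3 (0.16 log units; within the scatter) in this assay on the core of compound 1. The two groups have the same count of heavy atoms and the same ring type, and this one exchange, which removes a methyl and brings in a bromine, gives a difference that cannot be told from the scatter. Nothing measured here offers an explanation for how the two groups compare.

The compounds shown leave open whether a group that is not a substituted thiophene, such as a phenyl ring or a furan, or a ring carrying an amine or a carboxylic acid, would give a step beyond the scatter on this carbonyl carbon. They also cannot separate the loss of the methyl from the gain of the bromine, a question that an unsubstituted thiophen-2-yl on the same core would address.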